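Taking the nitro group off compound 1

The source may report more compounds than this note shows. Statements on the series, on what has been measured and on what is new or still open speak of the compounds shown alone.

Measured in a functional assay on KYSE-450 cells (Homo sapiens) for inhibition, read by MTT assay, with a stated time of 48 h; on this read-out higher numbers stand for weaker inhibition and lower numbers for stronger inhibition (three compounds so far)
Compound 1 `C/C=C/C(=O)N(Cc1ccc(OC)c([N+](=O)[O-])c1)c1cc(OC)c(OC)c(OC)c1` gives 510 nM
Compound 2 `COc1ccc(CNc2cc(OC)c(OC)c(OC)c2)cc1[N+](=O)[O-]` gives 16800 nM
Compound 3 `COc1ccc(CN(C(C)=O)c2cc(OC)c(OC)c(OC)c2)cc1O` gives 160 nM

Compound 1 holds the middle of these three numbers: compound 3 sits lower and compound 2 much higher. The next compound to be measured is compound 4 `C/C=C/C(=O)N(Cc1ccc(OC)cc1)c1cc(OC)c(OC)c(OC)c1`, which differs from compound 1 by a single change, hydrogen in place of nitro on an aromatic carbon.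

Among the measured compounds shown here, no measured step touches that aromatic carbon. For the measured compounds named here, the only step available (a 33-fold higher number from compound 1 to compound 2 (1.52 log units; beyond the scatter)) is large, but it is hydrogen in place of (prop-1-en-1-yl)carbonyl on a nitrogen on an aromatic ring, and compound 4 keeps that carbonyl group. A change of that size is therefore not expected. Compound 3, which carries no nitro group, still gives a low number (160 nM), although it differs from compound 1 in more than one place. A modest rise in this assay is expected, with its direction only weakly supported (a 2.4-fold higher number from compound 1 to compound 4 (0.37 log units; beyond the scatter)). Compound 4 is estimated at 1200 nM (expected range 300 nM to 5000 nM).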

Compound 4, half-maximal inhibitory concentration: 420 nM
Beside the measured number, compound 4's estimate is 2.9-fold (0.46 log units) above it, and the stated range covers the measured number.
By their numbers in this assay, from the lowest: compound 3; then compounds 4 and 1 (each within the scatter of the next); then compound 2.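

In this assay, hydrogen in place of nitro on the aromatic carbon ortho to a methoxy group gives a 1.2-fold lower number from compound 1 to compound 4 (0.08 log units; within the scatter), so the two numbers cannot be told apart and the nitro group is not required for a number of this size in the core of compound 1. Among the compounds shown here, this is the first measured step at this aromatic carbon, and it sets the position apart from the nitrogen on the aromatic ring, where hydrogen in place of (prop-1-en-1-yl)carbonyl gives a 33-fold higher number from compound 1 to compound 2 (1.52 log units; beyond the scatter), a large step beyond the scatter. Nothing shown gives a measured reason why the nitro group and hydrogen read alike here.

The compounds shown leave open whether an amino group, a fluorine atom or a nitrile on this aromatic carbon would also give a number close to that of compound 1 or would move it beyond the scatter. They also leave open whether hydrogen in place of nitro would be as silent when the nitrogen carries no (prop-1-en-1-yl)carbonyl group, as in compound 2, since this single step was read with that carbonyl group in place.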